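Replacing the imidazolylmethyl sulfide with an ester-bearing chain

The source may hold more compounds than are shown below. What is called first, only, known or untested is meant among the compounds shown, and "the series" means these compounds.

Among the compounds with values here, compound 2 `N#Cc1c(N)nc(SCc2cnc[nH]2)c(C#N)c1-c1ccc(OCC2CC2)cc1` gives 1% in an assay on CHO cells for displacement of a labelled ligand from adenosine receptor A1 (Homo sapiens), read by scintillation counting, with a stated time of 90 min, tested at 1 uM (a lower number here means less inhibition, a higher number more inhibition at the concentration tested (going by the name of the read-out)), the lowest of the two numbers known; its nearest neighbour is compound 1 `N#Cc1c(N)nc(SCc2nc3ccccc3[nH]2)c(C#N)c1-c1ccc(OCC2CC2)cc1`, which gives 21% in this assay. Compound 3 `COC(=O)CSc1nc(N)c(C#N)c(-c2ccc(OCC3CC3)cc2)c1C#N` differs from compound 2 by methoxycarbonyl in place of 1H-imidazol-5-yl on a saturated chain carbon bound to a sulfur. Within the data shown here, the one measured step, a number 20 percentage points lower from compound 1 to compound 2 (beyond the scatter), exchanged one ring for another and does not speak directly to a ring giving way to an ester. With compound 2 already near the floor, compound 3 is expected to stay within the scatter, a step of a number 7 percentage points higher from compound 2 to compound 3 (within the scatter), giving an estimated 8% (range 0% to 25%).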

Compound 3, a percentage reported as inhibition, at one concentration (the size of the read-out at that concentration, not a potency): 23%
Compound 3: middle estimate off by 15 percentage points, on the low side; measured number inside the range.
By their numbers in this assay, from the lowest: compound 2; then compounds 1 and 3 (each within the scatter of the next).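

In this assay methoxycarbonyl in place of 1H-imidazol-5-yl gives a number 22 percentage points higher from compound 2 to compound 3 (beyond the scatter) and so a ring is not required on this saturated chain carbon bound to a sulfur. Methoxycarbonyl in place of 1H-benzimidazol-2-yl gives a number 2 percentage points higher from compound 1 to compound 3 (within the scatter) and so, of these three groups, only 1H-imidazol-5-yl stands apart. No available evidence bears on why these groups compare as they do.

The compounds shown leave open whether a carboxylic acid, a primary amide or a longer chain carrying the methyl ester would take the number beyond that of compound 3. They also leave open how these readings at a single concentration relate to potency.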